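Methoxy entry on the ethene series: compound 3 to compound 4

A few compounds are considered here, and "the series" means these few. Any claim that something is new, unique, unknown or untested is made for them only; others in the source may bear on it.

Working notes on four compounds sharing one ethene core. Compound 1 `CC/C(=C(/c1ccc(NC(=O)C(C)C)cc1)c1ccc(OC)cc1)c1ccc(OCc2ccccc2)cc1` gives 29000 nM in a functional assay on MCF7 cells (Homo sapiens) for inhibition, read by trypan blue exclusion, with a stated time of 72 h; on this read-out higher numbers stand for weaker inhibition of growth and lower numbers for stronger inhibition of growth. Compound 2 `CC/C(=C(\c1ccc(NC(=O)C(C)C)cc1)c1ccc(OC)cc1)c1ccccc1` gives 27900 nM in this assay. Compound 3 `CC/C(=C(/c1ccccc1)c1ccc(NC(=O)C(C)C)cc1)c1ccc(OCc2ccccc2)cc1` stands apart: in this assay compound 3 is reported only as a limit, > 30000 nM, so no number for it is known. This is the one case of the limit of > 30000 nM in this assay, at which 1 of the 3 values shown sits, among the values shown. Going by the values given here, no pair of measured compounds differs in a single place, so no measured step is available to calibrate the next change.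

Compound 4 `CC/C(=C(\c1ccc(NC(=O)C(C)C)cc1)c1ccc(OC)cc1)c1ccc(OCc2ccccc2)cc1` differs from compound 3 by methoxy in place of hydrogen on an aromatic carbon. Compound 1 and compound 2 both already carry this methoxy and sit close to the limit at which compound 3 is reported. On that ground the step from compound 3 to compound 4 is expected to be small, if present at all, and any direction is uncertain: an expected at least 1.0-fold lower number from compound 3 to compound 4 (0.02 log units; that floor lies within the scatter) in this assay. Compound 4 is estimated at 28000 nM in this assay, with a range from 14000 nM to 60000 nM, and a fair chance that only a limit is reported.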

Compound 4, concentration for 50% growth inhibition: > 30000 nM
Compound 4 was reported as a limit (the forecaster's own chance of this, stated with the estimate: 40%); middle value at least 1.0-fold (0.02 log units) from the limit.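

In this assay compound 4 is reported only as a limit, > 30000 nM. The step for methoxy in place of hydrogen, on an aromatic carbon para to a large group, cannot be read, since both of its ends are limits, so this change brings no readable number into the series: the limit of > 30000 nM in this assay, at which 2 of the 4 values shown sit.

Two steps can be read only as floors. The added benzyloxy group gives an at least 1.0-fold higher number from compound 2 to compound 4 (0.03 log units; that floor lies within the scatter), and the change of drawn double-bond configuration gives an at least 1.0-fold higher number from compound 1 to compound 4 (0.01 log units; that floor lies within the scatter), so neither floor shows a change beyond the scatter, and the second of these pairs is the first comparison of the two drawn forms on this substitution pattern: the fact that compounds 1 and 4 differ only in the configuration as drawn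

On these data alone, how far compound 3 and compound 4 actually lie from each other stays open, as does any true size of the methoxy step. As far as these compounds go, whether a hydroxyl or an aminoethoxy chain in place of the methoxy at this position would give a measured number rather than a limit also stays open.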